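A few compounds are considered here, and "the series" means these few. Any claim that something is new, unique, unknown or untested is made for them only; others in the source may bear on it.

Measured compounds:
compound 1, `ClCc1ccccc1Cn1cnc2c(Cl)nc(Cl)nc21`, 1230 nM
compound 2, `ClCc1ccccc1Cn1cnc2c(Cl)ncnc21`, 2240 nM
compound 3, `ClCc1ccc(Cn2cnc3nc(Cl)nc(Cl)c32)cc1`, 1990 nM

The study concerns three chlorinated purine derivatives tested in a functional assay on OVCAR-8 cells (Homo sapiens) for cytotoxicity, read by sulforhodamine B assay, with a stated time of 48 h; a higher number here means a weaker inhibitor of growth, a lower number a stronger inhibitor of growth. In this assay compound 1 gives 1230 nM. Compound 2 is obtained from compound 1 by one change, (hydrogen in place of chloro on an aromatic carbon), and this change produced a 1.8-fold higher number from compound 1 to compound 2 (0.26 log units; within the scatter). Compound 3 carries the same atoms as compound 1 joined differently; the difference between the two cores is not broken down here. In this assay compound 3 gives 1990 nM, while compound 1 gives 1230 nM and compound 2 gives 2240 nM.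

Compound 4, `ClCc1ccc(Cn2cnc3ncnc(Cl)c32)cc1`, has not yet been measured. It stands to compound 3 as compound 2 stands to compound 1: the change is hydrogen in place of chloro on an aromatic carbon, and the surroundings of the place are the same in every respect, so it is the same change seen twice among these compounds. Among the compounds with values here, the only guide to its effect is the step from compound 1 to compound 2, which was a 1.8-fold higher number from compound 1 to compound 2 (0.26 log units; within the scatter). On that basis the step from compound 3 to compound 4 is expected to be a 1.8-fold higher number from compound 3 to compound 4 (0.26 log units; within the scatter), because the earlier step was a 1.8-fold higher number from compound 1 to compound 2 (0.26 log units; within the scatter). Compound 4 is therefore estimated to give 3600 nM in this assay, with a plausible range from 1800 nM to 7500 nM.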

Compound 4, concentration for 50% growth inhibition: 3160 nM
For compound 4 the middle estimate is 1.1-fold (0.06 log units) above the measured one, within the range that was stated.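

In this assay the replacement of chloro by hydrogen on the aromatic carbon between two ring nitrogen atoms gives a 1.6-fold higher number from compound 3 to compound 4 (0.20 log units; within the scatter) on the core of compound 3. Set beside the same replacement on the core of compound 1, the step carries over from one core to the other without a detectable difference: the same change on two cores in this assay, a 1.8-fold higher number (0.26 log units; within the scatter) from compound 1 to compound 2 and a 1.6-fold higher number (0.20 log units; within the scatter) from compound 3 to compound 4, 1.1-fold (0.06 log units) apart, within the scatter of two such steps. Within the data shown here, this agreement shows only that the two steps cannot be told apart on these two cores; each step lies within the scatter on its own, so the pair does not establish that the replacement changes the growth-inhibition reading on either core, and it says nothing about any core beyond these two.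

The compounds shown leave open how a group other than chloro or hydrogen at this place, such as an amine, a methoxy group or a longer chain, would read in this assay on either core. They also leave open what happens when the other chloro group, the one on the same ring that all four compounds keep, gives way to an amine or to hydrogen, and whether the chloromethyl group can be exchanged for a plain methyl or a hydroxymethyl group.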